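Replacing the nitro group of the most potent compound

The compounds below may be only part of what the source reports. "The series", "measured", "known", "first", "only" and "open" are said of these compounds alone.

Within the data shown here, in a functional assay on L1210 cells (Mus musculus) for antiproliferative activity (a lower number here means a stronger inhibitor, a higher number a weaker inhibitor), compound 3 (`COc1cc(C(=O)c2sc(-c3cccc([N+](=O)[O-])c3)cc2N)cc(OC)c1OC`) gives 11 nM and has the lowest of the three numbers measured so far. Compound 1 (`COc1cc(C(=O)c2sc(-c3ccc([N+](=O)[O-])cc3)cc2N)cc(OC)c1OC`) gives 100 nM and compound 2 (`COc1cc(C(=O)c2sc(-c3ccc(I)cc3)cc2N)cc(OC)c1OC`) gives 400 nM on the same core.

Compound 4 (`COc1cc(C(=O)c2sc(-c3ccc(Cl)c(Cl)c3)cc2N)cc(OC)c1OC`) carries 3,4-dichlorophenyl in place of 3-nitrophenyl on an aromatic carbon next to the ring sulfur (3,4-dichlorophenyl in place of 3-nitrophenyl on an aromatic carbon). Among the measured compounds shown here, three measured steps bear on this change. Moving from 4-nitrophenyl to 3-nitrophenyl gave a modest step (a 9.1-fold lower number from compound 1 to compound 3 (0.96 log units; beyond the scatter)). Iodo in place of nitro gave another modest step (a 4.0-fold higher number from compound 1 to compound 2 (0.60 log units; beyond the scatter)), and the gap between the two extremes is large (a 36-fold lower number from compound 2 to compound 3 (1.56 log units; beyond the scatter)). Compound 4 has no nitro group and carries halogen, as compound 2 does, so a higher number is expected, a step of modest to large size. The expected change is an 11-fold higher number from compound 3 to compound 4 (1.04 log units; beyond the scatter) in this assay as estimated here. Compound 4 is expected to give 120 nM with an estimated range from 30 nM to 500 nM in this measurement.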

Compound 4, half-maximal inhibitory concentration: 260 nM
For compound 4 the middle estimate is 2.2-fold (0.34 log units) below the measured one; measured number inside the range.
By their numbers in this assay, from the lowest: compound 3; then compound 1; then compounds 4 and 2 (each within the scatter of the next).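

In this assay, replacing 3-nitrophenyl with 3,4-dichlorophenyl gave a 24-fold higher number from compound 3 to compound 4 (1.37 log units; beyond the scatter), so the low number of compound 3 was not kept by this second halogen-bearing aryl group. Set against 4-iodophenyl, the 3,4-dichlorophenyl group gave a 1.5-fold lower number from compound 2 to compound 4 (0.19 log units; within the scatter), which leaves the two halogen-bearing compounds indistinguishable, whereas against 4-nitrophenyl it gave a 2.6-fold higher number from compound 1 to compound 4 (0.41 log units; beyond the scatter). Among these four compounds, both halogen-bearing groups therefore give higher numbers than both nitrophenyl groups, and 3-nitrophenyl alone reaches the low end of the range.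

On these data alone, it remains open whether a nitrile, a carboxylic acid or an amine in place of the nitro group of 3-nitrophenyl would hold that low number. Nothing available here explains these differences.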